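The compounds below may be only part of what the source reports. "The series", "measured", "known", "first", "only" and "open" are said of these compounds alone.

Measured compounds:
- compound 1, `CCNC(=O)Nc1sc2ccccc2c1C(=O)N1CCN(C2CCN(C(=O)CC(C)C)CC2)CC1` — in a functional assay on HepG2 cells (Homo sapiens) for inhibition, read by scintillation counting, with a stated time of 2 h (on this read-out lower numbers stand for stronger inhibition and higher numbers for weaker inhibition), compound 1 has no result reported, given as "not determined" (no result reported)
- compound 2, `CCNC(=O)Nc1sc2ccccc2c1C(=O)N1CCN(C2CCN(C(=O)C3CCCCC3)CC2)CC1` — compound 2 gives 146 nM
- compound 3, `CCNC(=O)Nc1sc2ccccc2c1C(=O)N1CCN(C2CCN(C(=O)C(C)(C)C)CC2)CC1` — compound 3 gives 450 nM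

Compound 1 therefore stands nowhere on the numbers: no single value is available for it, and the step from compound 1 to compound 4 cannot be anchored to its own reading. The change to compound 4, `CCNC(=O)Nc1sc2ccccc2c1C(=O)N1CCN(C2CCN(C(=O)OC(C)(C)CF)CC2)CC1`, is a group of 6 heavy atoms (4 carbon, 1 oxygen, 1 fluorine; no ring) in place of a group of 4 heavy atoms (4 carbon; no ring), on a carbonyl carbon. Within the data shown here, only one measured step touches this part of the series: a 3.1-fold higher number from compound 2 to compound 3 (0.49 log units; beyond the scatter), which shows that exchanging one group on this carbonyl carbon for another of similar size moves the read-out by a modest amount. The group entering in compound 4 is closer in shape to the tert-butyl of compound 3 than to the cyclohexyl of compound 2, so the reading is expected to lie near the value of compound 3 rather than that of compound 2, with no firm direction against compound 1. Compound 4 is estimated at 350 nM, in the range 120 nM to 1100 nM.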

Compound 4, half-maximal inhibitory concentration: 61 nM
Compound 4: middle estimate off by 5.7-fold (0.76 log units), on the high side, outside the stated range (below it).
By their numbers in this assay, from the lowest: compound 4; then compound 2; then compound 3.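

In this assay the group of 6 heavy atoms (4 carbon, 1 oxygen, 1 fluorine; no ring) gives a 7.4-fold lower number from compound 3 to compound 4 (0.87 log units; beyond the scatter) and also a 2.4-fold lower number from compound 2 to compound 4 (0.38 log units; beyond the scatter) at this carbonyl carbon, both steps beyond the scatter. The only earlier step here was a rise, so this position is now shown to allow a number lower than with cyclohexyl, and with a group that has no ring, which makes compound 4 the lowest of the three compounds with values. No measured data are available to account for the change.

Among these compounds, compound 1 has no result, so no step involving it can be read, and isobutyl remains unplaced. Also open, going by these compounds, is how a tert-butoxy group, without the fluorine, or a dimethylamino group would read on this carbonyl carbon, which would separate the contribution of the fluorine from that of the oxygen.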